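Swapping the Aryl Group on Compound 1

This account rests on a few compounds, and the source may have more. Where it says the series, first, only, none or still open, it means among the compounds named here.

Compound 1 `CCc1ccc(C(Nc2ccccn2)c2ccc3cccnc3c2O)cc1` gives 170 nM in an assay for inhibition of protein disulfide-isomerase (Homo sapiens), with a stated time of 1 h (a higher number here means a weaker inhibitor, a lower number a stronger inhibitor), the lowest of the three numbers shown. Compound 3 `Oc1c(C(c2ccc3c(c2)CCC3)N2CCCCC2)ccc2ccoc12` gives 410 nM, and compound 2 `CCc1ccc(C(Nc2cc(C)ccn2)c2ccc3cccnc3c2O)cc1` gives 5390 nM; the step of a 32-fold higher number from compound 1 to compound 2 (1.50 log units; beyond the scatter) came from a methyl in place of hydrogen on an aromatic carbon. Compound 4 `Oc1c(C(Nc2ccccn2)c2ccccc2Cl)ccc2cccnc12` differs from compound 1 by 2-chlorophenyl in place of 4-ethylphenyl on a saturated chain carbon bound to an aromatic carbon and a nitrogen on an aromatic ring. Among the compounds with values here, no measured step touches this aryl group: the one step on record sits elsewhere, and compound 3 differs from compound 1 in more than one place, so it gives no clean guide. The expected step is a 2.4-fold higher number from compound 1 to compound 4 (0.37 log units; beyond the scatter), a mild weakening carrying wide uncertainty. Compound 4 is estimated at 400 nM, within 100 nM to 2000 nM.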

Compound 4, half-maximal inhibitory concentration: 500 nM
Compound 4: the middle estimate sits 1.3-fold (0.10 log units) below what was measured, within the range that was stated.
By their numbers in this assay, from the lowest: compound 1; then compounds 3 and 4 (each within the scatter of the next); then compound 2.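

The aryl group on the saturated chain carbon now has a measured step: 2-chlorophenyl in place of 4-ethylphenyl gives a 2.9-fold higher number from compound 1 to compound 4 (0.47 log units; beyond the scatter). This shows that the group can change in both its substituent and the substituent's place on the ring at a modest cost, while compound 4 stays far closer to compound 1 than compound 2 does. Nothing measured here explains the step. Because both features changed at once, the compounds shown cannot separate the loss of ethyl from the arrival of chlorine. A plain phenyl group at this place would help to separate them.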